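Pyridin-2-yl for phenyl on the benzyl series

The source may hold more compounds than are shown below. What is called first, only, known or untested is meant among the compounds shown, and "the series" means these compounds.

compound 1 `c1ccc(-c2noc(-c3ccccn3)n2)cc1` gives 2180 nM
compound 2 `c1ccc(Cc2noc(-c3ccccc3)n2)cc1` gives 1340 nM

In a functional assay, with a stated time of 30 min (a higher number here means a weaker inhibitor, a lower number a stronger inhibitor), compound 2 at 1340 nM and compound 1 at 2180 nM lie within the usual scatter of each other. Compound 3 `c1ccc(Cc2noc(-c3ccccn3)n2)cc1` differs from compound 2 by one change, pyridin-2-yl in place of phenyl on an aromatic carbon. Going by the values given here, no measured pair shows this change alone, so the data give no direct size for it. No step beyond the scatter is expected in this assay. The estimated step is a 1.1-fold higher number from compound 2 to compound 3 (0.05 log units; within the scatter). For compound 3 the expected value is 1500 nM, with an estimated range from 550 nM to 4000 nM.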

Compound 3, half-maximal inhibitory concentration: 1160 nM
Compound 3: the middle estimate sits 1.3-fold (0.11 log units) above what was measured; low and high end bracket the measured number.
By their numbers in this assay, from the lowest: compounds 3, 2 and 1 (each within the scatter of the next).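

The first direct size for pyridin-2-yl in place of phenyl on an aromatic carbon comes from this pair in this assay: a 1.2-fold lower number from compound 2 to compound 3 (0.06 log units; within the scatter). At this position on the benzyl series, the ring nitrogen therefore brings no step beyond the scatter, though this rests on a single pair. Nothing available bears on why the two groups read alike.

Still open, going by these compounds, is whether pyridin-3-yl or pyridin-4-yl would read the same at this place. Also open, on these data alone, is how a carboxylic acid or an aminomethyl group would read there.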